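A few compounds are considered here, and "the series" means these few. Any claim that something is new, unique, unknown or untested is made for them only; others in the source may bear on it.

Compound 1 `Cc1ccc(Oc2ccc(/C=N\NC(=O)c3ccncc3)cc2)cc1` gives 3.65 in a physicochemical assay for lipophilicity, in phosphate buffer, measured as octanol-water partition, with a stated time of 24 h; a higher number here means a more lipophilic compound, a lower number a more polar compound.
Compound 2 `O=C(N/N=C\c1ccc(Oc2ccc([N+](=O)[O-])cc2)cc1)c1ccncc1` gives 3.23 in this assay.
Compound 3 `O=C(N/N=C\c1ccc(Oc2ccc3ccccc3c2)cc1)c1ccncc1` gives 4.52 in this assay.

Compound 2 stands lowest of the three numbers in this assay. Its nearest neighbour is compound 1, which gives 3.65, a number beyond the scatter above compound 2; the furthest is compound 3, which gives 4.52, well above both.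

Compound 4 `O=C(N/N=C\c1ccc(Oc2ccc(F)cc2)cc1)c1ccncc1` has not yet been measured in this assay. It differs from compound 2 in one place: fluoro in place of nitro on an aromatic carbon, on an aromatic carbon of a six-membered aromatic ring of carbon only, para to a large group.

Within the data shown here, only one measured step bears on this change. From compound 1 to compound 2 the number moved by a number 0.42 log units lower from compound 1 to compound 2 (beyond the scatter), that is, putting nitro in place of methyl lowered the read-out by a modest amount beyond the scatter. The step to compound 4 removes that same nitro and puts in fluoro instead. Reversing the nitro is therefore expected to raise the number again, though fluoro is not methyl, so the full return to compound 1 is not expected. The expected step from compound 2 to compound 4 is a number 0.22 log units higher from compound 2 to compound 4 (within the scatter), a rise that may sit at the edge of the scatter. Compound 4 is estimated at 3.45, with a range from 3.15 to 3.8.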

Compound 4, partition coefficient: 3.5
Beside the measured number, compound 4's estimate is 0.05 log units below it, within the range that was stated.
By their numbers in this assay, from the lowest: compounds 2, 4 and 1 (each within the scatter of the next, the first and the last beyond it); then compound 3.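

Fluoro in place of nitro on an aromatic carbon (a number 0.27 log units higher from compound 2 to compound 4 (within the scatter)) and methyl exchanged for fluoro (a number 0.15 log units lower from compound 1 to compound 4 (within the scatter)) both leave the number in this assay within the scatter. Compound 4 therefore cannot be told apart from either compound 2 or compound 1, although those two are separated by a step beyond the scatter (a number 0.42 log units lower from compound 1 to compound 2 (beyond the scatter)), so at this position, para to a large group, fluoro adds a third substituent without resolving where it stands relative to the other two. Nothing given here explains any of these numbers, and no measurement offers a reason for them.

Going by these compounds, what remains open is how other groups at this same place would read in this assay, for instance an amine, a carboxylic acid, a methoxy group or a longer chain, and whether any of them would step clearly beyond the scatter from compound 4. Also open, on these data alone, is whether a chloro or bromo group would stay as close to compound 4 as compound 1 and compound 2 do.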